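Aryl Replacements on the Piperazine of a Triazine Core

The compounds below may be only part of what the source reports. "The series", "measured", "known", "first", "only" and "open" are said of these compounds alone.

Compound 1, `CC1CC(C)CN(c2nc(Nc3ccc(C#N)c(C(F)(F)F)c3)nc(Oc3ccnc4ccccc34)n2)C1`, gives 27200 nM in a functional assay on DU-145 cells (Homo sapiens) for cytotoxicity, read by sulforhodamine B assay, with a stated time of 48 h; a higher number here means a weaker inhibitor of growth, a lower number a stronger inhibitor of growth.
Compound 2, `CCN1CCN(c2nc(Nc3ccc(C#N)c(C(F)(F)F)c3)nc(Oc3ccnc4ccccc34)n2)CC1`, gives 86600 nM in this assay.
Compound 3, `COc1ccc(CN2CCN(c3nc(Nc4ccc(C#N)c(C(F)(F)F)c4)nc(Oc4ccnc5ccccc45)n3)CC2)c(OC)c1OC`, reaches only a limit of this assay, > 100000 nM.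

Among the plain numbers compound 2 stands highest, with compound 1 nearest: a 3.2-fold higher number from compound 1 to compound 2 (0.50 log units; beyond the scatter). The unmeasured compound 4, `N#Cc1ccc(Nc2nc(Oc3ccnc4ccccc34)nc(N3CCN(c4ccccc4F)CC3)n2)cc1C(F)(F)F`, differs from compound 2 by 2-fluorophenyl in place of ethyl on an amine nitrogen in a ring. The measured step closest to this change is an at least 1.1-fold higher number from compound 2 to compound 3 (0.06 log units; that floor lies within the scatter), in which a large aromatic group was also added at the same ring nitrogen and the number did not clearly move; only the limit of > 100000 nM in this assay, at which 1 of the 3 values shown sits, bounds it. A step in this assay of no clear size beyond the scatter is therefore expected, if anything toward a higher number. The expected step from compound 2 to compound 4 is a 1.1-fold higher number from compound 2 to compound 4 (0.04 log units; within the scatter). Compound 4 is estimated to give 95000 nM, between 30000 nM and 300000 nM.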

Compound 4, concentration for 50% growth inhibition: > 100000 nM
Compound 4 gave a limit, no number; the forecaster's own chance of this, stated with the estimate: 40%; middle value at least 1.0-fold (0.02 log units) from the limit.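

In this assay compound 4 also reaches only a limit, > 100000 nM. Compound 3 and compound 4 both carry an aromatic ring on this side of the ring nitrogen, and in compound 4 the 2-fluorophenyl sits directly on that nitrogen, yet neither gives a plain number. The change gives an at least 1.1-fold higher number from compound 2 to compound 4 (0.06 log units; that floor lies within the scatter), and its true size cannot be read: the limit of > 100000 nM in this assay, at which 2 of the 4 values shown sit.

Still open, from the compounds shown here alone, is whether a smaller group on this nitrogen, such as methyl or a hydroxyethyl chain, gives a lower number than compound 2 does. Also open, going by these compounds, is what a plain phenyl without the fluorine would give.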